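This account rests on a few compounds, and the source may have more. Where it says the series, first, only, none or still open, it means among the compounds named here.

Compound 2 `COc1cc2c(cc1OC)C(CC(=O)NC(C)(C)C)CC2` stands lowest of the three numbers measured in a functional assay on the whole organism (strain Swiss albino) for inhibition, with Mus musculus as the target, in the writhing test, with stated times of 60 min and 15 min, at a dose of 100 mg/kg by the oral route; a lower number here means less inhibition, a higher number more inhibition at the dose given (going by the name of the read-out): compound 2 gives 41.8%, while compound 1 `COc1cc2c(cc1OC)C(CC(=O)O)CC2` gives 44% and compound 3 `CCCCCNC(=O)CC1CCc2cc(OC)c(OC)cc21` gives 71.7%. The step to compound 4 `COc1cc2c(cc1OC)C(CC(=O)N1CCOCC1)CC2` changes the amide: morpholin-4-yl in place of (tert-butyl)amino on a carbonyl carbon. Among the compounds with values here, two measured steps touch the same carbonyl carbon. The step of a number 2.2 percentage points lower from compound 1 to compound 2 (within the scatter) shows that one amide in place of the acid changed little, whereas a number 29.9 percentage points higher from compound 2 to compound 3 (beyond the scatter) shows that a pentyl chain on the amide nitrogen brought a modest rise. Neither step tests a ring on that nitrogen, so compound 4 is expected to sit near compound 2, with a step of a number 6.2 percentage points higher from compound 2 to compound 4 (within the scatter) that may not clear the scatter. Compound 4 is estimated at 48%, within 28% to 68%.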

Compound 4, a percentage reported as inhibition, in the whole organism at one dose (the size of the read-out at that dose, not a potency): 23.6%
Compound 4: the middle estimate sits 24.4 percentage points above what was measured, outside the stated range (below it).
By their numbers in this assay, from the lowest: compound 4; then compounds 2 and 1 (each within the scatter of the next); then compound 3.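

In this assay, morpholin-4-yl in place of hydroxy on the carbonyl carbon gave a number 20.4 percentage points lower from compound 1 to compound 4 (beyond the scatter), so a change here can lower the number as well as raise it. The same ring gave a number 18.2 percentage points lower from compound 2 to compound 4 (beyond the scatter) and a number 48.1 percentage points lower from compound 3 to compound 4 (beyond the scatter), showing that the group on the amide nitrogen matters, not just the presence of an amide. Nothing measured here bears on why the number fell. From the compounds shown here alone, it remains open whether the fall goes with the ring, its oxygen or the missing amide hydrogen; a piperidin-1-yl or diethylamino group on this carbonyl carbon would help tell these apart.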